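Shifting a fluorine around the shared core

The source may report more compounds than this note shows. Statements on the series, on what has been measured and on what is new or still open speak of the compounds shown alone.

Of the compounds shown here, three with the same core have been measured. In a functional assay on DU-145 cells (Homo sapiens) for inhibition (a lower number here means a stronger inhibitor, a higher number a weaker inhibitor), compound 1 `Oc1ccc(-c2cc(-c3ccc(F)cc3)cc(-c3ccccc3O)n2)cc1` gives only a limit, > 50000 nM. Compound 2 `Oc1ccc(-c2cc(-c3ccccc3F)cc(-c3cccc(O)c3)n2)cc1` gives 3160 nM in this assay, and compound 3 `Oc1ccc(-c2cc(-c3cccc(F)c3)cc(-c3cccc(O)c3)n2)cc1` gives 2700 nM. Within the data shown here, the only step between measured compounds, a 1.2-fold lower number from compound 2 to compound 3 (0.07 log units; within the scatter), is small: compound 3 and compound 2 sit within the scatter of each other, and the remaining value shown is a limit, not a number, so compound 3 has no neighbour at a measurable distance.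

Compound 4 `Oc1ccc(-c2cc(-c3ccc(F)cc3)cc(-c3cccc(O)c3)n2)cc1` differs from compound 3 in one place: 4-fluorophenyl in place of 3-fluorophenyl on an aromatic carbon. Among the measured compounds shown here, the one measured step that bears on this change, a 1.2-fold lower number from compound 2 to compound 3 (0.07 log units; within the scatter), moved the fluorine once around its ring and changed the number only within the scatter. Compound 1 also carries a 4-fluorophenyl group, but it differs from compound 4 in a second place as well, so its limit says little on its own. On this evidence the expected step of a 1.0-fold higher number from compound 3 to compound 4 (0.02 log units; within the scatter) is none beyond the scatter, and compound 4 is estimated at 2800 nM, between 1000 nM and 9000 nM.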

Compound 4, half-maximal inhibitory concentration: 15200 nM
For compound 4 the middle estimate is 5.4-fold (0.73 log units) below the measured one; measured number outside the range, above it.
By their numbers in this assay, from the lowest: compounds 3 and 2 (each within the scatter of the next); then compound 4. At a limit, above all of these: compound 1.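

Moving the fluorine did not always leave the number unchanged: at this position, opposite the ring nitrogen, the 4-fluorophenyl group gives a 5.6-fold higher number from compound 3 to compound 4 (0.75 log units; beyond the scatter), and against the 2-fluorophenyl group it gives a 4.8-fold higher number from compound 2 to compound 4 (0.68 log units; beyond the scatter), so only the 4-fluorophenyl compound stands apart, as the weaker inhibitor. Compound 1 gives only a limit, not a number: the limit of > 50000 nM in this assay, at which 1 of the 4 values shown sits. Even so, with 3-hydroxyphenyl in place of 2-hydroxyphenyl the step reads as an at least 3.2-fold lower number from compound 1 to compound 4 (0.51 log units; beyond the scatter), so the 4-fluorophenyl group alone does not set the place of compound 1.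

The compounds shown leave open whether this weakening is tied to fluorine or would also follow a chlorine, a methoxy group or an amine on that ring. They also leave open whether a plain phenyl group there would sit nearer compound 3 or compound 4.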